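The source may report more compounds than this note shows. Statements on the series, on what has been measured and on what is new or still open speak of the compounds shown alone.

Compound 1 `Cc1n[nH]c(C)c1Oc1c(O)cc(O)c2c(=O)cc(-c3ccc(N4CCN(c5ccccn5)CC4)cc3)oc12` gives 1200 nM in an assay on cells for inhibition of ubiquitin carboxyl-terminal hydrolase 8 (Homo sapiens), read by fluorescence, with a stated time of 30 min; a lower number here means a stronger inhibitor, a higher number a weaker inhibitor. Compound 2 `Cc1n[nH]c(C)c1Oc1c(O)cc(O)c2c(=O)cc(-c3ccc(N4CCCNCC4)cc3)oc12` gives 17600 nM in this assay, and compound 3 `COc1c(O)cc(O)c2c(=O)cc(-c3ccc(N4CCCNCC4)cc3)oc12` gives 31600 nM. Compound 3 therefore carries the highest number of the three: its gap from compound 2 lies within the scatter, while compound 1 sits far below it, beyond the scatter. Compound 4 `COc1c(O)cc(O)c2c(=O)cc(-c3ccc(N4CCN(C=O)CC4)cc3)oc12` has not yet been measured. It differs from compound 3 in a single place: 4-formylpiperazin-1-yl in place of 1,4-diazepan-1-yl on an aromatic carbon. The measured step that bears on this change is a 15-fold higher number from compound 1 to compound 2 (1.17 log units; beyond the scatter), in which a substituted piperazine gave way to a 1,4-diazepan-1-yl group and the number rose sharply. Compound 4 returns to a piperazine, though the substituent is now formyl rather than pyridin-2-yl, so only part of that difference may be recovered. The step of a 1.8-fold higher number from compound 2 to compound 3 (0.25 log units; within the scatter) shows that the methyl for pyrazolyl swap elsewhere changes little. Compound 4 is therefore expected to give 10000 nM in this assay, with a range from 4000 nM to 30000 nM. That would correspond to an estimated 3.2-fold lower number from compound 3 to compound 4 (0.50 log units; beyond the scatter).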

Compound 4, half-maximal inhibitory concentration: 2200 nM
Compound 4: middle estimate off by 4.5-fold (0.66 log units), on the high side; the whole stated range lies above it.
By their numbers in this assay, from the lowest: compounds 1 and 4 (each within the scatter of the next); then compounds 2 and 3 (each within the scatter of the next).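

In this assay, the change on the aromatic carbon para to a large group is not tied to a pyridin-2-yl substituent: with methyl on the oxygen, 4-formylpiperazin-1-yl in place of 1,4-diazepan-1-yl gives a 14-fold lower number from compound 3 to compound 4 (1.16 log units; beyond the scatter). Across the two pairs that differ at this position, the 1,4-diazepan-1-yl compound carries the higher number each time, since the earlier step was a 15-fold higher number from compound 1 to compound 2 (1.17 log units; beyond the scatter) and both steps lie beyond the scatter. No measurement at hand explains why the number falls with this change.

The step joins a seven-membered ring giving way to a six-membered one with the arrival of the formyl group, so the compounds shown do not separate the two. An unsubstituted piperazin-1-yl group or a formyl group on the 1,4-diazepan-1-yl ring would address this, and the same holds for an acetyl group on the piperazine.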